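A few compounds are considered here, and "the series" means these few. Any claim that something is new, unique, unknown or untested is made for them only; others in the source may bear on it.

In a functional assay on MGC-803 cells (Homo sapiens) for antiproliferative activity, read by CCK-8 assay, with a stated time of 72 h, tested at 2 uM (a higher number here means a stronger effect of the compound at the concentration tested, a lower number a weaker effect), compound 2 `CC1CCCCN1C(=S)SCc1ccc(C(=O)Nc2ccccc2N)cc1` gives 64.4%. Among the three measured compounds it stands second highest: compound 3 `Nc1ccccc1NC(=O)c1ccc(CSC(=S)N2CCN(c3ccncc3)CC2)cc1` gives 64.8%, a value within the scatter of compound 2, while compound 1 `Nc1ccccc1NC(=O)c1ccc(CSC(=S)N2CCN(C3CCCCC3)CC2)cc1` gives 16.9%, a number beyond the scatter below it. Among the compounds with values here, the only measured one-place step is a number 47.9 percentage points higher from compound 1 to compound 3 (beyond the scatter); it alters a group on an amine nitrogen in a ring rather than the group attached to the thiocarbonyl carbon, so it does not bear directly on the change considered here, though it does show that the read-out can swing widely. Compound 4 `Nc1ccccc1NC(=O)c1ccc(CSC(=S)N2CCc3cc(Cl)ccc32)cc1` differs from compound 2 by 5-chloro-2,3-dihydro-1H-indol-1-yl in place of 2-methylpiperidin-1-yl on a thiocarbonyl carbon. Within the data shown here, compounds 2 and 3 carry very different groups at the thiocarbonyl carbon yet give values within the scatter of each other, and no measured step tests this position itself. On that basis the estimate for compound 4 is 60%, with a range from 30% to 85%. This corresponds to an expected step of a number 4.4 percentage points lower from compound 2 to compound 4 (within the scatter), none beyond the scatter, though the range is wide.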

Compound 4, a percentage reported as inhibition, at one concentration (the size of the read-out at that concentration, not a potency): 57.7%
Compound 4: the middle estimate sits 2.3 percentage points above what was measured; the measured number falls inside the stated range.
By their numbers in this assay, from the lowest: compound 1; then compounds 4, 2 and 3 (each within the scatter of the next).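

In this assay, within the data shown here, putting 5-chloro-2,3-dihydro-1H-indol-1-yl in place of 2-methylpiperidin-1-yl on a thiocarbonyl carbon gives a number 6.7 percentage points lower from compound 2 to compound 4 (within the scatter), the first measured step at this position. The entering group brings a six-membered aromatic ring and a chlorine that the leaving group lacks, yet the read-out stays within the usual scatter. This one pair therefore shows that this position accepts this particular exchange without a clear change in the effect at the tested concentration, though that says nothing about potency. No supporting measurement is available to explain why the step is so small.

A compound with plain 2,3-dihydro-1H-indol-1-yl, without the chlorine, would separate the contribution of the chlorine from that of the rings. An open-chain diethylamino group on the thiocarbonyl carbon would test whether a ring is needed there at all.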